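The source may hold more compounds than are shown below. What is called first, only, known or untested is meant among the compounds shown, and "the series" means these compounds.

Working notes on the series. Compound 1 `O=c1[nH]c(=O)n(COC(CO)CO)cc1O` stands only at a limit in a functional assay on SW-620 cells (Homo sapiens) for inhibition, read by MTT assay, with a stated time of 72 h (a higher number here means a weaker inhibitor, a lower number a stronger inhibitor), with no number of its own. In this assay compound 1 gives > 100000 nM, which is a limit of the assay and not a measured number. Compound 2 `Cn1cc(CO)c(N)nc1=O` is the other measured member. In this assay compound 2 gives > 100000 nM, again a limit rather than a number. For the measured compounds named here, both values therefore sit at the limit of > 100000 nM in this assay, at which 2 of the 2 values shown sit, and no step between measured compounds can be drawn from them. Compound 3 `O=C(CCl)Nc1cn(COC(CO)CO)c(=O)[nH]c1=O` has not been measured. It differs from compound 1 by ((chloromethyl)carbonyl)amino in place of hydroxy on an aromatic carbon. With compound 1 known only as a limit, the step from compound 1 to compound 3 cannot be anchored; the expectation is that compound 3 most likely also returns a limit, with a weak gain possible, so the expected step of an at least 1.6-fold lower number from compound 1 to compound 3 (0.22 log units; that floor lies within the scatter) is uncertain in size. Compound 3 is estimated at 60000 nM, within a range from 5000 nM to 300000 nM.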

Compound 3, half-maximal inhibitory concentration: 19000 nM
Compound 3: middle estimate off by 3.2-fold (0.50 log units), on the high side; low and high end bracket the measured number.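

In this assay, for the compounds shown here, ((chloromethyl)carbonyl)amino in place of hydroxy on this aromatic carbon gives the first step that can be read: an at least 5.2-fold lower number from compound 1 to compound 3 (0.72 log units; beyond the scatter). The earlier compounds shown here showed no value off the limit, whereas this result shows that a change at this position alone can bring a measurable number. Compound 1 remains a limit and not a number, so the step gives only a floor and its full size stays unknown: the limit of > 100000 nM in this assay, at which 2 of the 3 values shown sit.

The compounds shown do not tell whether the step depends on the chloromethyl end or on the carbonylamino link to the core. From the compounds shown here alone, an amine or an acetylamino group on the same aromatic carbon would separate the two, and the effect of a longer chain in place of chloromethyl also remains open.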